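This account rests on a few compounds, and the source may have more. Where it says the series, first, only, none or still open, it means among the compounds named here.

Measured compounds:
compound 1, `Cn1c(N2N=C(c3ccccc3)CC2c2ccc(F)cc2)nc(-c2ccccc2)c(C#N)c1=O`; in a functional assay on MDA-MB-231 cells (Homo sapiens) for antiproliferative activity, with a stated time of 72 h (a higher number here means a weaker inhibitor, a lower number a stronger inhibitor), compound 1 gives 11800 nM.
compound 2, `Cn1c(N2N=C(c3ccccc3)CC2c2ccccc2)nc(-c2ccc(Cl)cc2)c(C#N)c1=O`; in this assay compound 2 gives 29100 nM.
compound 3, `Cn1c(N2N=C(c3ccccc3)CC2c2ccc(F)cc2)nc(-c2ccc(Cl)cc2)c(C#N)c1=O`; in this assay compound 3 gives 20900 nM.

Compounds 1 and 3 differ in one place, (chloro in place of hydrogen on an aromatic carbon), and this change gave a 1.8-fold higher number from compound 1 to compound 3 (0.25 log units; within the scatter). Compounds 2 and 3 also differ in one place, and that pair gave a 1.4-fold lower number from compound 2 to compound 3 (0.14 log units; within the scatter). How the core of compound 2 differs from the core of compound 1 is not broken down here; the values alone show that compound 2 lies beyond the scatter from compound 1.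

Compound 4, `Cn1c(N2N=C(c3ccc(Cl)cc3)CC2c2ccccc2)nc(-c2ccc(Cl)cc2)c(C#N)c1=O`, has not been measured. It differs from compound 2 by chloro in place of hydrogen on an aromatic carbon, the same change as that from compound 1 to compound 3, with the place described in the same words. That change occurs twice among the compounds here, once measured. For the measured compounds named here, with only one measured instance, and that one within the scatter, the expectation rests on it loosely: the step from compound 2 to compound 4 in this assay is expected to be a 1.4-fold higher number from compound 2 to compound 4 (0.14 log units; within the scatter), because the earlier instance gave a 1.8-fold higher number from compound 1 to compound 3 (0.25 log units; within the scatter). For compound 4 the value in this assay is estimated at 40000 nM, with a range expected from 18000 nM to 90000 nM. Compound 2 itself gives 29100 nM in this assay, the highest of the three measured numbers here.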

Compound 4, half-maximal inhibitory concentration: 12400 nM
Estimate against measurement, compound 4: 3.2-fold (0.51 log units) above; measured number below the stated range.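

In this assay, for the compounds shown here, the change from phenyl to 4-chlorophenyl gave a 2.3-fold lower number from compound 2 to compound 4 (0.37 log units; beyond the scatter), a modest step towards stronger inhibition and the opposite direction to the one the earlier pair suggested. Set beside that earlier pair, the same change does not carry over as one fixed step between these two cores: the same change on two cores in this assay, a 1.8-fold higher number (0.25 log units; within the scatter) from compound 1 to compound 3 and a 2.3-fold lower number (0.37 log units; beyond the scatter) from compound 2 to compound 4, 4.2-fold (0.62 log units) apart, beyond the scatter of two such steps

This shows that, in these two pairs, the outcome of adding the chloro group differs with its surroundings, but with a single step on each core it gives no rule for a further core, and it does not show which structural difference is responsible, since the phenyl that changes is not the same phenyl in the two pairs and the partner compounds also differ in their other substituents.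

The compounds shown leave open whether the step from compound 2 to compound 4 is particular to chloro or whether another group at the same place, such as methoxy, an amine or a carboxylic acid, would shift the number in the same direction. They also leave open whether compound 4 would change further if the chloro group on its other phenyl were replaced by hydrogen.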